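The source may hold more compounds than are shown below. What is called first, only, known or untested is meant among the compounds shown, and "the series" means these compounds.

Measured compounds:
- compound 1, `Cc1ccc(C(=O)Nc2cc(-c3ccccc3)nn2-c2ccccc2)cc1`, with 30 nM in an assay on CHO cells with metabotropic glutamate receptor 5 (Homo sapiens) as the target; a higher number here means that more compound is needed for the effect, a lower number that less compound is needed
- compound 2, `O=C(Nc1cc(-c2ccccc2)nn1-c1ccccc1)c1ccccc1Cl`, with 2500 nM in this assay
- compound 3, `O=C(Nc1cc(-c2ccccc2)nn1-c1ccccc1)c1ccccn1`, with 290 nM in this assay

Compound 3 holds the second highest number of the three. Its nearest neighbour is compound 2, from which it lies an 8.6-fold lower number from compound 2 to compound 3 (0.94 log units; beyond the scatter); its furthest is compound 1, from which it lies a 9.7-fold higher number from compound 1 to compound 3 (0.99 log units; beyond the scatter). Compound 4, `O=C(Nc1cc(-c2ccccc2)nn1-c1ccccc1)c1cccc(F)c1`, has not yet been measured. Its change from compound 3 is 3-fluorophenyl in place of pyridin-2-yl on a carbonyl carbon.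

For the measured compounds named here, two measured steps bear on this move, both touching the same carbonyl carbon. Replacing 4-methylphenyl with pyridin-2-yl raised the number a 9.7-fold higher number from compound 1 to compound 3 (0.99 log units; beyond the scatter), while replacing 2-chlorophenyl with pyridin-2-yl lowered it an 8.6-fold lower number from compound 2 to compound 3 (0.94 log units; beyond the scatter). Returning from pyridin-2-yl to a carbon-only ring therefore points both ways: toward compound 1 when the ring carried a 4-methyl, toward compound 2 when it carried a 2-chloro. A 3-fluorophenyl is neither, so a modest step downward from compound 3, with wide uncertainty, is expected: a 2.9-fold lower number from compound 3 to compound 4 (0.46 log units; beyond the scatter). Compound 4 is estimated at 100 nM, in a range from 25 nM to 400 nM.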

Compound 4, half-maximal effective concentration: 20 nM
Beside the measured number, compound 4's estimate is 5.0-fold (0.70 log units) above it; measured number below the stated range.
By their numbers in this assay, from the lowest: compounds 4 and 1 (each within the scatter of the next); then compound 3; then compound 2.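

For the compounds shown here, on the carbonyl carbon, 3-fluorophenyl in place of pyridin-2-yl gives a 15-fold lower number from compound 3 to compound 4 (1.16 log units; beyond the scatter) in this assay, and 3-fluorophenyl in place of 2-chlorophenyl gives a 130-fold lower number from compound 2 to compound 4 (2.10 log units; beyond the scatter) as the widest step so far, so this position responds strongly not only to the swap of a ring nitrogen for carbon but also to which halogen-bearing phenyl ring is attached. The third new step, 3-fluorophenyl in place of 4-methylphenyl, gives a 1.5-fold lower number from compound 1 to compound 4 (0.18 log units; within the scatter) and stays within the usual scatter, which means that two differently substituted carbon-only rings cannot be told apart here, while compound 2 goes against any reading that a carbon-only ring on this carbonyl is enough for a low number. The compounds shown offer no measurement that accounts for any of these steps.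

As far as these compounds go, what remains open is whether the gap between compound 2 and compound 4 belongs to the chlorine, to the fluorine or to where each sits on the ring, as no other substituted phenyl ring appears. Nor do these compounds show how the carbonyl position would respond to a saturated ring such as morpholine, to an amine, to a carboxylic acid or to a longer alkyl chain in place of an aromatic ring.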